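A few compounds are considered here, and "the series" means these few. Any claim that something is new, unique, unknown or untested is made for them only; others in the source may bear on it.

Compound 1 `OCc1cn(CCNc2nonc2/C(=N/O)Nc2ccc(F)c(Br)c2)nn1` and compound 2 `OCCCc1cn(CCNc2nonc2/C(=N/O)Nc2ccc(F)c(Br)c2)nn1` share one core and differ only in the chain that carries the hydroxyl. In an assay on isolated protein for inhibition of Indoleamine 2,3-dioxygenase 2 (Homo sapiens) (on this read-out lower numbers stand for stronger inhibition and higher numbers for weaker inhibition), compound 1 gives 794 nM, and compound 2 gives 958 nM; the change a 1.2-fold higher number from compound 1 to compound 2 (0.08 log units; within the scatter) leaves the two numbers indistinguishable, so compound 1 simply stands at the lower of two values that are within the scatter of each other.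

Compound 3 `O/N=C(\Nc1ccc(F)c(Br)c1)c1nonc1NCCn1cc(C2(O)CCCCC2)nn1` is not yet measured in this assay. It differs from compound 1 by 1-hydroxycyclohexyl in place of hydroxymethyl on an aromatic carbon. Among the compounds with values here, the only step that bears on this is the one from compound 1 to compound 2, which showed that altering the hydroxyl-bearing substituent at that position produced no shift beyond the scatter. On that basis compound 3 is expected to give a number close to compound 1, with an estimated step of a 1.1-fold higher number from compound 1 to compound 3 (0.05 log units; within the scatter). The estimate for compound 3 in this assay is 900 nM, with a range from 300 nM to 2700 nM.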

Compound 3, half-maximal inhibitory concentration: 865 nM
Beside the measured number, compound 3's estimate is 1.0-fold (0.02 log units) above it, and the stated range covers the measured number.
By their numbers in this assay, from the lowest: compounds 1, 3 and 2 (each within the scatter of the next).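

In this assay, 1-hydroxycyclohexyl in place of hydroxymethyl gives a 1.1-fold higher number from compound 1 to compound 3 (0.04 log units; within the scatter), so at this aromatic carbon, a group of 7 heavy atoms with a six-membered non-aromatic ring leaves the number within the scatter of that for the 2-heavy-atom group. The open chain and the ring also cannot be told apart on this read-out, as 1-hydroxycyclohexyl in place of 3-hydroxypropyl gives a 1.1-fold lower number from compound 2 to compound 3 (0.04 log units; within the scatter). No measurement is at hand that would account for this tolerance of the larger group.

All three groups shown carry a hydroxyl, so it remains open how plain cyclohexyl, with no hydroxyl, would compare at this position. As far as these compounds go, an amine or a carboxylic acid in the hydroxyl's place is equally open.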